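Ethoxy replaces the amino group on compound 1's carbonyl

The source may report more compounds than this note shows. Statements on the series, on what has been measured and on what is new or still open speak of the compounds shown alone.

In a functional assay on MOLT-4 cells (Homo sapiens) (on this read-out higher numbers stand for weaker inhibition and lower numbers for stronger inhibition), compound 1 (`COc1cc(NC(C)CCCNC(=O)NC(CO)(CO)CO)c2ncccc2c1`) gives > 100000 nM as its result, and this is a limit of the assay rather than a number. Compound 2 (`COc1cc(N2C(=O)NCCCC2C)c2ncccc2c1`) gives >= 100000 nM in this assay and this, too, is a limit. Compound 1 therefore has no numerical standing, and the only other result available is also a limit. Within the data shown here, no measured pair of compounds differing in one place is available as a guide.

Compound 3 (`CCOC(=O)NCCCC(C)Nc1cc(OC)cc2cccnc12`) has not yet been measured. It carries ethoxy in place of (2-hydroxy-1,1-bis(hydroxymethyl)ethyl)amino on a carbonyl carbon while keeping the core of compound 1. Among the measured compounds shown here, with no measured step to draw on, only a modest move toward stronger inhibition is expected in this assay and the result may again be only a limit. An estimated at least 2.0-fold lower number from compound 1 to compound 3 (0.30 log units; that floor lies within the scatter) is expected. Compound 3 is estimated at 50000 nM within an expected range of 15000 nM to 120000 nM on this read-out.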

Compound 3, half-maximal inhibitory concentration: 34000 nM
Compound 3: the middle estimate sits 1.5-fold (0.17 log units) above what was measured; the measured number falls inside the stated range.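

Among these compounds, on the carbonyl carbon whose other neighbour is an amide-type nitrogen, ethoxy in place of (2-hydroxy-1,1-bis(hydroxymethyl)ethyl)amino gives the first actual number in this assay, with compound 3 at 34000 nM. The change produces an at least 2.9-fold lower number from compound 1 to compound 3 (0.46 log units; beyond the scatter), which shows that inhibition in this assay responds to the group at this place, something the two earlier limits could not show. The true size of this step remains unknown, because the result for compound 1 is a limit and not a number: the limit of > 100000 nM in this assay, at which 1 of the 3 values shown sits.

The change removes a larger group and its hydrogen-bond donors in a single step, so the compounds shown do not separate these two differences. Going by these compounds, it also remains open whether a methylamino group or a tert-butoxy group on the same carbonyl carbon would match ethoxy, and so whether the oxygen that ethoxy brings to this place matters at all.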